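Second Methoxy on the Core of Compound 1

A few compounds are considered here, and "the series" means these few. Any claim that something is new, unique, unknown or untested is made for them only; others in the source may bear on it.

Measured compounds:
Compound 1 `COc1ccnc(Nc2ccc(Cl)c(OCC=C(C)C)c2)n1`: 9000 nM
Compound 2 `CC(C)=CCOc1cc(Nc2nccc(N)n2)ccc1Cl`: 500 nM
Compound 3 `CC(C)=CCOc1cc(Nc2nccc(CO)n2)ccc1Cl`: 220 nM

In a functional assay on MT2 cells (Homo sapiens) for cytotoxicity, read by MTT assay (a higher number here means that more compound is tolerated, a lower number that less compound is tolerated), compound 1 stands highest of the three, so it is the best tolerated compound in this set. The measured steps leave from it: an 18-fold lower number from compound 1 to compound 2 (1.26 log units; beyond the scatter) and a 41-fold lower number from compound 1 to compound 3 (1.61 log units; beyond the scatter), both large. Between the two lower compounds, a 2.3-fold lower number from compound 2 to compound 3 (0.36 log units; beyond the scatter) is modest.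

Compound 4 `COc1cc(OC)nc(Nc2ccc(Cl)c(OCC=C(C)C)c2)n1` keeps the methoxy of compound 1 and changes only in one place: methoxy in place of hydrogen on an aromatic carbon. Among the compounds with values here, no measured step bears directly on this change; both steps already seen replace the methoxy rather than add a second one, so they tell how much is lost when the methoxy goes, not what a further methoxy does. With nothing in the data pointing in either direction, a step within the usual scatter is expected, and the estimated step is no change at the digits printed from compound 1 to compound 4 (within the scatter). Compound 4 is therefore expected to give about 9000 nM in this assay, within the range 3000 nM to 27000 nM.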

Compound 4, half-maximal cytotoxic concentration: 28000 nM
Beside the measured number, compound 4's estimate is 3.1-fold (0.49 log units) below it; the measured number lies above the stated range.
By their numbers in this assay, from the lowest: compound 3; then compound 2; then compound 1; then compound 4.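

In this assay, the aromatic carbon next to the ring nitrogen turns out to matter: a methoxy in place of its hydrogen gives a 3.1-fold higher number from compound 1 to compound 4 (0.49 log units; beyond the scatter) and so moves the number upward, whereas replacing the existing methoxy in compound 2 and compound 3 moved it downward. The core of compound 1 can therefore shift this number in either direction, and this is the only upward step among the compounds shown. Nothing measured here accounts for the rise.

Going by these compounds, this rests on a single step, so it remains open whether the rise is particular to methoxy or would also appear with a methyl, a chlorine atom or an amine on the same carbon. An ethoxy there would show whether a longer chain carries the number further.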